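Series notes: methyl to hydrogen against an unbroken limit

This account rests on a few compounds, and the source may have more. Where it says the series, first, only, none or still open, it means among the compounds named here.

Measured so far:
Compound 1, `CCCC/C=C\CCCCCCCCCc1cc(=O)c2c(O)cc(OCOC)cc2o1`, in a functional assay on MDA-MB-231 cells (Homo sapiens) for antiproliferative activity, read by MTT assay (on this read-out lower numbers stand for stronger inhibition and higher numbers for weaker inhibition), gives > 87000 nM, a limit of the assay.
Compound 2, `CCCC/C=C\CCCCCCCCCc1cc(=O)c2c(O)c(C)c(OCOC)cc2o1`, in this assay gives > 87000 nM, also a limit.
Compound 3, `CCCCCCCCCCCCCCCc1cc(=O)c2c(O)c(C)c(O)c(C)c2o1`, in this assay gives > 87000 nM, again a limit.

All three values sit at the limit of > 87000 nM in this assay, at which 3 of the 3 values shown sit, so no number is read for any of them. From compound 2 to compound 1 the change is hydrogen in place of methyl on an aromatic carbon; the step that the two limits leave unreadable from compound 2 to compound 1 cannot be sized from two limits. How the core of compound 3 differs from that of compound 2 is not broken down here.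

Compound 4, `CCCCCCCCCCCCCCCc1cc(=O)c2c(O)c(C)c(O)cc2o1`, is not yet measured in this assay. From compound 3 it differs by hydrogen in place of methyl on an aromatic carbon, the same kind of change as from compound 2 to compound 1, though the surroundings differ: in compound 4 the place is ortho to a fused ring, ortho to a hydroxy group, meta to a methyl group and para to a hydroxy group, whereas in compound 1 it is ortho to a methoxymethoxy group and para to a fused ring. The earlier step of this kind was unreadable. Compound 4 is expected to remain at the limit, with the expected step that the limit leaves unreadable from compound 3 to compound 4 meaning no readable change. The estimate for compound 4 is 100000 nM, between 50000 nM and 300000 nM.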

Compound 4, half-maximal inhibitory concentration: 42800 nM
Compound 4: the middle estimate sits 2.3-fold (0.37 log units) above what was measured; measured number outside the range, below it.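

In this assay, hydrogen in place of methyl on an aromatic carbon gives an at least 2.0-fold lower number from compound 3 to compound 4 (0.30 log units; that floor lies within the scatter), so on the core of compound 3 this change is the only one here with a readable lower bound, and that bound does not clear the usual scatter. The same change on the core of compound 2 cannot be read, and neither the size of the step on that core nor any comparison with the step on the core of compound 3 is available, so nothing here shows that the change carries from one core to the other, or that it fails to: the limit of > 87000 nM in this assay, at which 3 of the 4 values shown sit. One pair with a floor inside the scatter establishes no trend for this change across the series.

Still open, on these data alone, is whether the change would give a readable step on a core carrying the methoxymethoxy group. Also open, as far as these compounds go, is how an amine or a carboxylic acid at the end of the chain, or a shorter chain, would read in this assay.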